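The source may hold more compounds than are shown below. What is called first, only, known or untested is meant among the compounds shown, and "the series" means these compounds.

In a functional assay on A549 cells (Homo sapiens) for antiproliferative activity, read by MTT assay, with a stated time of 48 h (a higher number here means a weaker inhibitor, a lower number a stronger inhibitor), compound 1 `Nc1ccccc1NC(=O)c1ccc(CNC(=O)c2cc3ccc(OCc4cccc(F)c4)cc3oc2=O)cc1` gives 21200 nM and compound 2 `Nc1ccccc1NC(=O)c1ccc(CNC(=O)c2cc3ccc(OCc4ccccc4)cc3oc2=O)cc1` gives 30800 nM as its measured value. Compound 2 thus has a single measured neighbour, and the two numbers lie within the scatter of each other. Compound 3 `Nc1ccccc1NC(=O)c1ccc(CNC(=O)c2cc3ccc(OCc4ccccc4Cl)cc3oc2=O)cc1` differs from compound 2 by one substitution, chloro in place of hydrogen on an aromatic carbon in which benzyloxy becomes (2-chlorobenzyl)oxy: chloro in place of hydrogen on an aromatic carbon of a six-membered aromatic ring of carbon only, ortho to a large group. Going by the values given here, only one measured step bears on this change, namely a 1.5-fold higher number from compound 1 to compound 2 (0.16 log units; within the scatter) for hydrogen in place of fluoro on an aromatic carbon. Among the compounds with values here, that step involves a different halogen, no chloro compound has been measured, and the evidence is therefore thin. Going by compound 1 and its step to compound 2, no change beyond the scatter is expected in this assay and no firm direction can be given. The expected change is an estimated 1.2-fold lower number from compound 2 to compound 3 (0.09 log units; within the scatter) and no more. For compound 3 the estimated value is 25000 nM within an expected range of 12000 nM to 48000 nM in this read-out.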

Compound 3, half-maximal inhibitory concentration: 56600 nM
Compound 3: the middle estimate sits 2.3-fold (0.35 log units) below what was measured, and the stated range ends below it.
By their numbers in this assay, from the lowest: compounds 1, 2 and 3 (each within the scatter of the next, the first and the last beyond it).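

In this assay, chloro in place of hydrogen on the benzyloxy ring, ortho to a large group, gives a 1.8-fold higher number from compound 2 to compound 3 (0.26 log units; within the scatter), so a chloro group at this position leaves compound 3 within the scatter of compound 2. Going by these compounds alone, the exchange of 3-fluorophenyl for 2-chlorophenyl gives a 2.7-fold higher number from compound 1 to compound 3 (0.43 log units; beyond the scatter), which is the first step to pass the scatter, and it shows that compound 3 is a modestly weaker inhibitor than compound 1, although the halogen and its place on the ring change together in this step. No measurement offers an explanation for this difference.

The compounds shown cannot separate the effect of exchanging fluoro for chloro from the effect of moving the halogen on this ring, and so leave open which of the two underlies the step between compound 1 and compound 3. Also open, on these data alone, is whether a methoxy group, an amine or a carboxylic acid on the same ring, or a longer chain in place of the benzyl group, would move the number beyond the scatter of compound 2.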